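The source may report more compounds than this note shows. Statements on the series, on what has been measured and on what is new or still open speak of the compounds shown alone.

Measured so far:
compound 1 `O=c1cc(Cn2cc(CCCCl)nn2)c2ccc(O)cc2o1` — 49600 nM
compound 2 `O=c1cc(Cn2cc(CCO)nn2)c2ccc(O)cc2o1` — > 100000 nM
compound 3 `CC(O)c1cn(Cc2cc(=O)oc3cc(O)ccc23)nn1` — > 100000 nM

In a functional assay on HeLa cells (Homo sapiens) for inhibition, read by MTT assay, with a stated time of 72 h (a lower number here means a stronger inhibitor, a higher number a weaker inhibitor), compound 1 gives 49600 nM. For compound 2 the read-out is a limit of the assay, > 100000 nM. For compound 3 the read-out is likewise a limit, > 100000 nM. Compound 3 thus stands only at a limit, one of two values sitting there (the limit of > 100000 nM in this assay, at which 2 of the 3 values shown sit).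

Compound 4 `O=c1cc(Cn2cc(CCCCO)nn2)c2ccc(O)cc2o1` differs from compound 3 by 4-hydroxybutyl in place of 1-hydroxyethyl on an aromatic carbon. Among the measured compounds shown here, the steps that bear on it are an at least 2.0-fold higher number from compound 1 to compound 3 (0.30 log units; that floor lies within the scatter) and a step that the two limits leave unreadable from compound 2 to compound 3 at the same place, and an at least 2.0-fold higher number from compound 1 to compound 2 (0.30 log units; that floor lies within the scatter) toward another hydroxy-bearing chain. All run upward or stay unreadable at the limit, so no step beyond the scatter is expected in this assay and compound 4 is expected to sit at the limit again, the step being estimated as a number no higher from compound 3 to compound 4 (the limit leaves the size open). Compound 4 is estimated at 100000 nM, range 40000 nM to 300000 nM.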

Compound 4, half-maximal inhibitory concentration: > 100000 nM
Compound 4 was reported as a limit; the forecaster's own chance of this, stated with the estimate: 70%; the middle value sits exactly at the limit.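

In this assay, compound 4, with 4-hydroxybutyl on the aromatic carbon of the five-membered ring, is again a limit, > 100000 nM. Hydroxymethyl in place of chloro at the chain end gives an at least 2.0-fold higher number from compound 1 to compound 4 (0.30 log units; that floor lies within the scatter), so even this chain-matched pair shows no change beyond the scatter. The steps among compound 2, compound 3 and compound 4 cannot be read, and the effect of hydroxy chain length stays hidden at one limit: the limit of > 100000 nM in this assay, at which 3 of the 4 values shown sit.

From the compounds shown here alone, whether the chloro end itself matters remains open. An amine or a carboxylic acid at the chain end, or a longer chloroalkyl chain, could test this.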